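The source may hold more compounds than are shown below. What is called first, only, known or untested is meant among the compounds shown, and "the series" means these compounds.

Of the compounds shown here, three built on one shared core have been tested in a functional assay on A549 cells (Homo sapiens) for inhibition, read by CCK-8 assay, with a stated time of 48 h; on this read-out higher numbers stand for weaker inhibition and lower numbers for stronger inhibition. Compound 1 `COc1ccc(-c2cc3nccc(-c4cc(OC)c(OC)c(OC)c4)n3n2)cc1N` gives 138 nM, which is the second highest of the three numbers. Compound 2 `COc1cc(-c2ccnc3cc(-c4ccc(C)cc4)nn23)cc(OC)c1OC` gives 3 nM, and compound 3 `COc1cc(-c2ccnc3cc(-c4ccc(Cl)cc4)nn23)cc(OC)c1OC` gives 3070 nM. Both measured steps that start from compound 1 replace the whole aryl group attached to the core: a 46-fold lower number from compound 1 to compound 2 (1.66 log units; beyond the scatter), whereas a 22-fold higher number from compound 1 to compound 3 (1.35 log units; beyond the scatter). Between those two new aryl groups, a 1000-fold higher number from compound 2 to compound 3 (3.01 log units; beyond the scatter). Compound 4 `COc1ccc(-c2cc3nccc(-c4cc(OC)c(OC)c(OC)c4)n3n2)cc1[N+](=O)[O-]` keeps the aryl group of compound 1 and alters only one substituent on it: nitro in place of amino on an aromatic carbon. Among the compounds with values here, no measured step swaps exactly these two groups, so the direction cannot be read off directly; still, every step in which this aryl group changes is large, so a step beyond the scatter is expected, more plausibly toward a higher number than a lower one. Compound 4 is therefore expected to give 450 nM, within a range from 60 nM to 3500 nM. This estimate means that a 3.3-fold higher number from compound 1 to compound 4 (0.51 log units; beyond the scatter) is expected.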

Compound 4, half-maximal inhibitory concentration: > 10000 nM
Compound 4 ended at the assay's limit; the forecaster's own chance of this, stated with the estimate: 5%; at least 22-fold (1.34 log units) between middle value and limit.
By their numbers in this assay, from the lowest: compound 2; then compound 1; then compound 3. At a limit, above all of these: compound 4.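

Within the data shown here, until this point, each step replaced the whole aryl group on the shared core; here only one substituent on that group changes, ortho to a methoxy group. In this assay, nitro in place of amino gives an at least 72-fold higher number from compound 1 to compound 4 (1.86 log units; beyond the scatter), so a change at this single position, with the rest of compound 1 left as it was, is enough to produce a large step. Compound 4 sits at a limit of the assay, so its entry is a limit and not a number: the limit of > 10000 nM in this assay, at which 1 of the 4 values shown sits.

These two compounds alone cannot tell whether the step comes from losing the amino group or from gaining the nitro group. The shown compounds also leave open how a plain hydrogen, a hydroxyl group or an acetamide would read at this same position.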